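Trifluoromethyl for trifluoromethoxy: what to expect of compound 4

This account rests on a few compounds, and the source may have more. Where it says the series, first, only, none or still open, it means among the compounds named here.

Three measured compounds share a common core and differ in their aromatic substituents. Compound 1 `O=C(Nc1cccc(C(F)(F)F)c1)c1cc(F)ccc1O`, compound 3 `O=C(Nc1cccc(OC(F)(F)F)c1)c1cc(F)ccc1O` and compound 2 `O=C(Nc1ccc(OC(F)(F)F)c(Cl)c1)c1cc(Cl)ccc1O` were all tested in a functional assay on HL-60 cells (Homo sapiens) for cytotoxicity, read by luminescence and CellTiter-Glo, with a stated time of 3 days; a higher number here means a weaker inhibitor, a lower number a stronger inhibitor. In this assay compound 1 gives 970 nM, compound 3 gives 730 nM and compound 2 gives 450 nM. The difference between the cores of compound 2 and compound 3 is not broken down here. Compound 2 and compound 3 lie within the scatter of each other, while compound 1 sits beyond the scatter from compound 2.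

One change is seen in a measured pair: trifluoromethyl in place of trifluoromethoxy on an aromatic carbon, and it produced a 1.3-fold higher number from compound 3 to compound 1 (0.12 log units; within the scatter).

Compound 4 `O=C(Nc1ccc(C(F)(F)F)c(Cl)c1)c1cc(Cl)ccc1O` has not yet been measured. It arises from compound 2 through (trifluoromethyl in place of trifluoromethoxy on an aromatic carbon). This is the same kind of change as that from compound 3 to compound 1, not the same change: in compound 3 the site is meta to a large group, whereas in compound 2 it is ortho to a chloro group and para to a large group.

The step from compound 2 to compound 4 is expected to be a 1.3-fold higher number from compound 2 to compound 4 (0.12 log units; within the scatter), because a 1.3-fold higher number from compound 3 to compound 1 (0.12 log units; within the scatter) was itself within the scatter. With that single precedent, compound 4 is estimated at 600 nM, with an expected range from 250 nM to 1400 nM.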

Compound 4, half-maximal inhibitory concentration: 460 nM
Beside the measured number, compound 4's estimate is 1.3-fold (0.12 log units) above it; the measured number falls inside the stated range.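

In this assay, putting trifluoromethyl in place of trifluoromethoxy on the core of compound 2 gives a 1.0-fold higher number from compound 2 to compound 4 (0.01 log units; within the scatter), so on this second core the change again stays inside the scatter. Set side by side, the two measured steps do not differ from each other: the same change on two cores in this assay, a 1.3-fold higher number (0.12 log units; within the scatter) from compound 3 to compound 1 and a 1.0-fold higher number (0.01 log units; within the scatter) from compound 2 to compound 4, 1.3-fold (0.11 log units) apart, within the scatter of two such steps. This shows that, on these two cores, the change behaves alike and leaves the number where it was within the scatter, even though in compound 2 the site is ortho to a chloro group and para to a large group; it does not show that the same would hold on any other core or in any other assay, and two pairs, both with steps this small, give no explanation of the agreement.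

The compounds shown leave open whether a different group at this site, such as a nitrile, an amine, a carboxylic acid or a longer chain, would shift the number beyond the scatter. The separate contribution of each chloro group in compound 2 and compound 4 also stays open, as no pair shown isolates either one.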